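Chromanone series: swapping the benzyloxy arm for methoxymethoxy

The source may report more compounds than this note shows. Statements on the series, on what has been measured and on what is new or still open speak of the compounds shown alone.

Of the compounds shown here, three have been measured in a functional assay on RAW264.7 cells (Mus musculus) for inhibition, read by immunoassay, with a stated time of 12 h, tested at 30 uM; on this read-out lower numbers stand for less inhibition and higher numbers for more inhibition at the one concentration tested (going by the name of the read-out). Compound 1 `O=C1CC(c2ccccc2OCc2ccccc2)Oc2ccccc21` gives 93.2%. Compound 2 `O=C1CC(c2ccccc2OCc2cccc(F)c2)Oc2ccccc21` gives 93.3%. Compound 3 `CC(C)c1ccc(COc2ccccc2C2CC(=O)c3ccccc3O2)cc1` gives 91.5%. The three numbers lie together: a number 0.1 percentage points higher from compound 1 to compound 2 (within the scatter), a number 1.7 percentage points lower from compound 1 to compound 3 (within the scatter) and a number 1.8 percentage points lower from compound 2 to compound 3 (within the scatter). Compound 3 thus stands within the scatter of both of the others, and no ordering among the three can be read from these numbers.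

Compound 4 `COCOc1ccccc1C1CC(=O)c2ccccc2O1` is unmeasured. The change from compound 3 is methoxy in place of 4-isopropylphenyl on a saturated chain carbon bound to an oxygen on an aromatic ring. Within the data shown here, only one measured step touches the same position: a number 1.8 percentage points lower from compound 2 to compound 3 (within the scatter), an exchange of one aromatic group for another at that saturated chain carbon, which stayed within the scatter. The step of a number 1.7 percentage points lower from compound 1 to compound 3 (within the scatter) altered the same aromatic group without moving the number either. Among the measured compounds shown here, no measured step removes the aromatic ring from that position and replaces it with a methoxy, so the present change has no direct precedent, and the high, flat numbers of compounds 1, 2 and 3 are the only guide.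

Compound 4 is therefore expected to give 82% in this assay, with a range from 58% to 95%. The corresponding step is estimated at a number 9.5 percentage points lower from compound 3 to compound 4 (within the scatter), with the lower end of the range allowing for a loss beyond the scatter.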

Compound 4, a percentage reported as inhibition, at one concentration (the size of the read-out at that concentration, not a potency): 35.2%
Estimate against measurement, compound 4: 46.8 percentage points above; measured number outside the range, below it.
By their numbers in this assay, from the lowest: compound 4; then compounds 3, 1 and 2 (each within the scatter of the next).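

The position on a saturated chain carbon bound to an oxygen on an aromatic ring, which stayed flat through exchanges of one aromatic group for another, is not indifferent to what sits there in this assay: methoxy in place of 4-isopropylphenyl gives a large loss (a number 56.3 percentage points lower from compound 3 to compound 4 (beyond the scatter)). The same holds from the other two aromatic groups, with methoxy in place of 3-fluorophenyl (a number 58.1 percentage points lower from compound 2 to compound 4 (beyond the scatter)) and methoxy in place of phenyl (a number 58 percentage points lower from compound 1 to compound 4 (beyond the scatter)), so all three routes to compound 4 agree and the earlier flat numbers held only among groups carrying an aromatic ring. No measurement in hand speaks to the reason for this drop.

Compound 4 differs from the others both in lacking the aromatic ring and in having a much smaller group, so the two changes cannot be told apart from these compounds. A cyclohexyl group or a longer chain such as n-butyl at the same saturated chain carbon would separate them, and a pyridyl group would test how far the aromatic exchange can go.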